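A few compounds are considered here, and "the series" means these few. Any claim that something is new, unique, unknown or untested is made for them only; others in the source may bear on it.

Compound 1 `Cc1cc(O)c(C2=NN(c3ccc(S(N)(=O)=O)cc3)C(c3ccccc3O)C2)cc1Cl` and compound 2 `Cc1cc(O)c(C2=NN(c3ccc(S(N)(=O)=O)cc3)C(/C=C/c3ccccc3)C2)cc1Cl` share a core and differ only on one saturated ring carbon. In a functional assay on NCI-H322M cells (Homo sapiens) for antiproliferative activity, with a stated time of 48 h (a higher number here means a weaker inhibitor of growth, a lower number a stronger inhibitor of growth), compound 1 gives 7240 nM, while compound 2 gives 27500 nM, the highest of the two numbers, and the step of a 3.8-fold higher number from compound 1 to compound 2 (0.58 log units; beyond the scatter) is modest. Compound 3 `COc1ccc(C2CC(c3cc(Cl)c(C)cc3O)=NN2c2ccc(S(N)(=O)=O)cc2)cc1OC` differs from compound 2 by 3,4-dimethoxyphenyl in place of 2-phenylethenyl on a saturated ring carbon. A directly attached aromatic ring, as in compound 1, gave a lower number than the 2-phenylethenyl group, so compound 3 is expected to move back toward that range, with a step of a 2.8-fold lower number from compound 2 to compound 3 (0.44 log units; beyond the scatter). Compound 3 is therefore estimated at 10000 nM, with a likely range from 3000 nM to 35000 nM.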

Compound 3, concentration for total growth inhibition: 39700 nM
Estimate against measurement, compound 3: 4.0-fold (0.60 log units) below, and the stated range ends below it.
By their numbers in this assay, from the lowest: compound 1; then compounds 2 and 3 (each within the scatter of the next).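

In this assay, 3,4-dimethoxyphenyl in place of 2-phenylethenyl on this saturated ring carbon gives a 1.4-fold higher number from compound 2 to compound 3 (0.16 log units; within the scatter) and so does not separate the two groups. In place of 2-hydroxyphenyl, the same group gives a 5.5-fold higher number from compound 1 to compound 3 (0.74 log units; beyond the scatter) and shows that an aromatic ring at this carbon does not by itself keep compound 3 in the range of compound 1. Nothing available explains this difference. Still open, going by these compounds, is how a plain phenyl, a 2-aminophenyl or a 2-carboxyphenyl group would compare at this carbon.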